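This account rests on a few compounds, and the source may have more. Where it says the series, first, only, none or still open, it means among the compounds named here.

Among the measured compounds shown here, compound 1 `CCC1=C(O)c2c(oc(-c3ccc(Br)cc3)cc2=O)C(CC)(CC)C1=O` is one of two compounds so far measured in a functional assay on KB cells (Homo sapiens) for antiproliferative activity, read by sulforhodamine B assay, with a stated time of 3 days; on this read-out lower numbers stand for an effect already at smaller amounts and higher numbers for an effect only at larger amounts of compound. In this assay compound 1 gives > 48.1 uM, which is a limit of the assay and not a number. Compound 2 `CCC1=C(O)c2c(oc(-c3cc(C)c(OC)cc3C)cc2=O)C(CC)(CC)C1=O`, built on the same core, gives 36.6 uM in this assay. Compound 1 therefore stands at the limit of > 48.1 uM in this assay, at which 1 of the 2 values shown sits, while compound 2 shows an effect only at a high concentration. Compound 3 `CCC1=C(O)c2c(oc(-c3cc(C)cc(C)c3)cc2=O)C(CC)(CC)C1=O` has not yet been measured in this assay. It differs from compound 1 by 3,5-dimethylphenyl in place of 4-bromophenyl on an aromatic carbon. For the measured compounds named here, no step between measured compounds shows how such a change acts here, so the expectation rests only on the two values shown, both of which point to an effect needing large amounts of compound. The estimated step of an at least 1.0-fold lower number from compound 1 to compound 3 (0.02 log units; that floor lies within the scatter) is expected to stay within the usual scatter. Compound 3 is expected to give 45 uM, within 18 uM to 110 uM, with a real chance that only a limit is reported.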

Compound 3, concentration for half-maximal effect: 45.5 uM
For compound 3 the middle estimate is 1.0-fold (0.00 log units) below the measured one; the range from low to high includes it.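

On the aromatic carbon next to the ring oxygen, 3,5-dimethylphenyl in place of 4-bromophenyl gives, in this assay, an at least 1.0-fold lower number from compound 1 to compound 3 (0.02 log units; that floor lies within the scatter). Among the compounds shown here, this is the first reading of a change at this position, but it gives only a floor, so the true size of the step stays unknown and no gain can be claimed. Compound 1 is the one compound that rests on a limit of the assay and not on a number: the limit of > 48.1 uM in this assay, at which 1 of the 3 values shown sits.

All the compounds shown carry a substituted phenyl at this position, so how a phenyl bearing an amine or a carboxylic acid would act stays open. Also open, on these data alone, is whether any group here can bring the effect down to much smaller amounts of compound.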